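Swapping nitro for fluoro on the chain-bound aryl group

The source may report more compounds than this note shows. Statements on the series, on what has been measured and on what is new or still open speak of the compounds shown alone.

Measured so far:
compound 1 `O=C1OC(c2ccc(Cl)cc2)=C/C1=C\c1ccccc1Cl`: 62.7%
compound 2 `O=C1OC(c2ccc(Cl)cc2)=C/C1=C\c1ccc(Cl)cc1`: 40%
compound 3 `O=C1OC(c2ccc(Cl)cc2)=C/C1=C\c1ccc([N+](=O)[O-])cc1`: 4%

All three share one core and were tested in a functional assay on the whole organism (strain Wistar) for inhibition, with Rattus norvegicus as the target, with stated times of 30 min and 2 h, at a dose of 20 mg/kg by the oral route; on this read-out lower numbers stand for less inhibition and higher numbers for more inhibition at the one dose given (going by the name of the read-out). Compound 3, with 4%, stands lowest of the three numbers, and both its neighbours lie beyond the scatter above it. Two steps are known. The change from compound 1 to compound 2 brought a number 22.7 percentage points lower from compound 1 to compound 2 (beyond the scatter), and the change from compound 2 to compound 3 brought a number 36 percentage points lower from compound 2 to compound 3 (beyond the scatter). Compound 4 `O=C1OC(c2ccc(Cl)cc2)=C/C1=C\c1ccc(F)cc1` differs from compound 3 in one place: fluoro in place of nitro on an aromatic carbon. The second measured step is the one that bears on this, since it removed chloro for nitro and the present step removes nitro again for a related small group. Going by these compounds, because compound 2 with chloro in that place gave 40%, the expected step is upward, in this assay a number 26 percentage points higher from compound 3 to compound 4 (beyond the scatter), though how closely fluoro will match chloro is unknown. Compound 4 is therefore estimated at 30%, within a range from 10% to 52%.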

Compound 4, a percentage reported as inhibition, in the whole organism at one dose (the size of the read-out at that dose, not a potency): 41.3%
Estimate against measurement, compound 4: 11.3 percentage points below; the range from low to high includes it.
By their numbers in this assay, from the lowest: compound 3; then compounds 2 and 4 (each within the scatter of the next); then compound 1.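

In this assay, nitro stands apart from both halogens at this place on the ring: fluoro in its place gives a number 37.3 percentage points higher from compound 3 to compound 4 (beyond the scatter) and restores a level like that of chloro, since the swap between the two halogens gives a number 1.3 percentage points higher from compound 2 to compound 4 (within the scatter) and so shows no real difference. The 2-chlorophenyl group also remains distinct from the 4-fluorophenyl group, with a number 21.4 percentage points lower from compound 1 to compound 4 (beyond the scatter) as the step, matching what the 4-chlorophenyl group showed earlier. No measured evidence here explains why nitro differs from the halogens.

The compounds shown leave open whether an amine or a carboxylic acid at this place would fall with the halogens or with nitro. They also leave open how these numbers would change at other doses.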